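The source may report more compounds than this note shows. Statements on the series, on what has been measured and on what is new or still open speak of the compounds shown alone.

Measured compounds:
compound 1 `COC(=O)C1=C(C)NC(=O)NC1c1ccoc1` gives 42%
compound 2 `CC(=O)C1=C(C)NC(=O)NC1c1ccoc1` gives 15%
compound 3 `CC1=C(C(=O)NC(C)C)C(c2ccoc2)NC(=O)N1` gives 3%

All three values come from an assay on membranes from HEK293 cells for displacement of a labelled ligand from adenosine receptor A2b (Homo sapiens), read by scintillation counting, with a stated time of 30 min, tested at 1 uM; a higher number here means more inhibition at the concentration tested (going by the name of the read-out), a lower number less inhibition. Compound 3 stands lowest of the three, with a number 39 percentage points lower from compound 1 to compound 3 (beyond the scatter) and a number 12 percentage points lower from compound 2 to compound 3 (beyond the scatter). Compound 4 `CC1=C(C(=O)OC2CCCCC2)C(c2ccoc2)NC(=O)N1` differs from compound 3 by cyclohexyloxy in place of isopropylamino on a carbonyl carbon. Within the data shown here, the step that bears most on this is the one from compound 1 to compound 3, a number 39 percentage points lower from compound 1 to compound 3 (beyond the scatter), which put the isopropylamino group in place of an alkoxy group on the carbonyl carbon; compound 4 reverses that kind of change, returning to an alkoxy group, though a larger one. A rise beyond the scatter is therefore expected, a number 32 percentage points higher from compound 3 to compound 4 (beyond the scatter). Compound 4 is estimated at 35%, within 12% to 60%.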

Compound 4, a percentage reported as inhibition, at one concentration (the size of the read-out at that concentration, not a potency): 4%
Compound 4: middle estimate off by 31 percentage points, on the high side, and the stated range ends above it.
By their numbers in this assay, from the lowest: compounds 3 and 4 (each within the scatter of the next); then compound 2; then compound 1.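

Cyclohexyloxy in place of isopropylamino gives a number 1 percentage points higher from compound 3 to compound 4 (within the scatter) on this carbonyl carbon, so an alkoxy group there does not by itself bring the read-out back. Cyclohexyl in place of methyl on the oxygen gives a number 38 percentage points lower from compound 1 to compound 4 (beyond the scatter) and cyclohexyloxy in place of methyl on the carbonyl carbon gives a number 11 percentage points lower from compound 2 to compound 4 (beyond the scatter) in this series, which leaves methoxy in compound 1 as the only group shown here that stands above all the others. Nothing on hand accounts for this result.

Going by these compounds, whether ethoxy or benzyloxy on this carbonyl carbon would fall nearer compound 1 or compound 4 remains open. So does the reading for a carboxylic acid at this place.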